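This account rests on a few compounds, and the source may have more. Where it says the series, first, only, none or still open, it means among the compounds named here.

Compound 1 `N#Cc1ccc(S(=O)(=O)N2C/C(=C\c3cccnc3)C(=O)/C(=C/c3ccccc3C(F)(F)F)C2)cc1` gives 13200 nM in an ADME assay on L02 cells (Homo sapiens) for cytotoxicity, read by MTT assay, with a stated time of 24 h; on this read-out lower numbers stand for stronger inhibition and higher numbers for weaker inhibition. Compound 2 `CC(=O)Nc1ccc(S(=O)(=O)N2C/C(=C\c3cccnc3)C(=O)/C(=C/c3ccccc3C(F)(F)F)C2)cc1` carries acetamido in place of cyano on an aromatic carbon and gives 15300 nM in this assay; that step is a 1.2-fold higher number from compound 1 to compound 2 (0.06 log units; within the scatter). Compound 3 `N#Cc1ccc(S(=O)(=O)N2C/C(=C\c3ccncc3)C(=O)/C(=C/c3ccccc3C(F)(F)F)C2)cc1` differs in its core by pyridin-4-yl in place of pyridin-3-yl on a double-bonded chain carbon bound to a double-bonded ring carbon; in this assay compound 3 gives 17600 nM, a step of a 1.3-fold higher number from compound 1 to compound 3 (0.12 log units; within the scatter). Compound 4 `CC(=O)Nc1ccc(S(=O)(=O)N2C/C(=C\c3ccncc3)C(=O)/C(=C/c3ccccc3C(F)(F)F)C2)cc1` has not been measured in this assay; it carries acetamido in place of cyano on an aromatic carbon, the same change that turned compound 1 into compound 2, at the same place. Because a 1.2-fold higher number from compound 1 to compound 2 (0.06 log units; within the scatter) was what that change did on the other core, the step for compound 4 is estimated at a 1.1-fold higher number from compound 3 to compound 4 (0.06 log units; within the scatter). Compound 4 is thus expected to give about 20000 nM in this assay, most likely somewhere from 11000 nM to 37000 nM.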

Compound 4, half-maximal inhibitory concentration: 10100 nM
Estimate against measurement, compound 4: 2.0-fold (0.30 log units) above; measured number outside the range, below it.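

In this assay, acetamido in place of cyano gives a 1.7-fold lower number from compound 3 to compound 4 (0.24 log units; within the scatter), and pyridin-4-yl in place of pyridin-3-yl gives a 1.5-fold lower number from compound 2 to compound 4 (0.18 log units; within the scatter). Carried from the core of compound 1 to the core of compound 3, the acetamido change shows no difference beyond the scatter: the same change on two cores in this assay, a 1.2-fold higher number (0.06 log units; within the scatter) from compound 1 to compound 2 and a 1.7-fold lower number (0.24 log units; within the scatter) from compound 3 to compound 4, 2.0-fold (0.31 log units) apart, within the scatter of two such steps. The pyridine change likewise shows no such difference between cores, yet with every step this small, the four compounds show only that no dependence on the core is detected, not that either change has a real effect that carries over: the same change on two cores in this assay, a 1.3-fold higher number (0.12 log units; within the scatter) from compound 1 to compound 3 and a 1.5-fold lower number (0.18 log units; within the scatter) from compound 2 to compound 4, 2.0-fold (0.31 log units) apart, within the scatter of two such steps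

The compounds shown leave open whether an amine or a carboxylic acid in place of cyano on that aromatic carbon would give a step beyond the scatter. They also leave open how such a step would behave on the two cores, or with pyridin-2-yl in place of pyridin-3-yl.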